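A few compounds are considered here, and "the series" means these few. Any claim that something is new, unique, unknown or untested is made for them only; others in the source may bear on it.

Notes on the series. Compound 1 `COc1cc(-c2ccnc3cc(-c4ccc5cc[nH]c5c4)nn23)cc(OC)c1OC` gives 23 nM in a functional assay on MCF7 cells (Homo sapiens) for inhibition, read by CCK-8 assay, with a stated time of 48 h; on this read-out lower numbers stand for stronger inhibition and higher numbers for weaker inhibition. Compound 2 `COc1cc(-c2ccnc3cc(-c4ccccc4)nn23)cc(OC)c1OC` gives 254 nM in this assay. Within the data shown here, on these two numbers compound 2 stands highest, with compound 1 as its only neighbour. Among the measured compounds shown here, the one recorded step, an 11-fold higher number from compound 1 to compound 2 (1.04 log units; beyond the scatter), goes with phenyl in place of 1H-indol-6-yl on an aromatic carbon.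

Compound 3 `COc1cc(-c2ccnc3cc(-c4cn(C)c5ccccc45)nn23)cc(OC)c1OC` is not yet measured in this assay. It differs from compound 2 by 1-methyl-1H-indol-3-yl in place of phenyl on an aromatic carbon. For the measured compounds named here, the step that bears on this is an 11-fold higher number from compound 1 to compound 2 (1.04 log units; beyond the scatter), since compound 3 again carries a fused indolyl group where compound 2 has phenyl; however, the group in compound 3 is 1-methyl-1H-indol-3-yl rather than 1H-indol-6-yl, so the change is not a plain reversal of that step, and no measured pair speaks to this particular indolyl. A lower number is therefore expected for compound 3, with the step of a 3.6-fold lower number from compound 2 to compound 3 (0.56 log units; beyond the scatter) kept smaller than the recorded gap back to compound 1 to allow for that uncertainty. Compound 3 is expected at 70 nM, within a range from 18 nM to 280 nM.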

Compound 3, half-maximal inhibitory concentration: 95 nM
The estimate for compound 3 lay 1.4-fold (0.13 log units) below the measured number; low and high end bracket the measured number.
By their numbers in this assay, from the lowest: compound 1; then compound 3; then compound 2.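

In this assay, a second fused group on this aromatic carbon also goes with a lower number than phenyl, a 2.7-fold lower number from compound 2 to compound 3 (0.43 log units; beyond the scatter), so the lower number is not confined to 1H-indol-6-yl. The two indolyl groups are not interchangeable here, however: a 4.1-fold higher number from compound 1 to compound 3 (0.62 log units; beyond the scatter), which shows that this position still distinguishes between two fused groups of similar type. Nothing at hand gives a reason for either step.

The change from 1H-indol-6-yl to 1-methyl-1H-indol-3-yl alters both the point of attachment and the methyl group at once, so the share of each stays unresolved; 1H-indol-3-yl and 1-methyl-1H-indol-6-yl would separate the two. Also open, on these data alone, is whether the fused second ring is needed at all, which a single-ring group such as pyridyl or a phenyl bearing an amine would address, and whether the three methoxy groups on the other aryl ring can be changed without losing the numbers seen with the indolyl groups.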